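A few compounds are considered here, and "the series" means these few. Any claim that something is new, unique, unknown or untested is made for them only; others in the source may bear on it.

Three members of the series have numbers in a functional assay on isolated protein for inhibition of Glucose-dependent insulinotropic receptor (Rattus norvegicus), read by HTRF and cAMP accumulation; on this read-out higher numbers stand for larger maximal responses and lower numbers for smaller maximal responses. Compound 1 `Cc1nc(S(C)(=O)=O)ccc1Oc1ncnc(OC2CCN(C(=O)OC3CCC3)CC2)c1F` gives 81%. In this assay compound 2 `Cc1nc(S(C)(=O)=O)ccc1Oc1ncnc(OC2CCN(C(=O)SC3CCC3)CC2)c1F` gives 81%. Compound 3 `Cc1nc(S(C)(=O)=O)ccc1Oc1ncnc(OC2CCN(C(=O)C(C)(C)F)CC2)c1F` gives 74% in this assay, the lowest of the three numbers, though its gaps to compound 1 and to compound 2 both lie within the scatter. The measured steps: no change at the digits printed from compound 1 to compound 2 (within the scatter); a number 7 percentage points lower from compound 1 to compound 3 (within the scatter); a number 7 percentage points lower from compound 2 to compound 3 (within the scatter). Each exchanges the group on the carbonyl carbon, and none moves the read-out beyond the scatter.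

Compound 4 `CCc1cnc(C(=O)N2CCC(Oc3ncnc(Oc4ccc(S(C)(=O)=O)nc4C)c3F)CC2)nc1` varies the same position: 5-ethylpyrimidin-2-yl in place of 1-fluoro-1-methylethyl on a carbonyl carbon. All three measured steps bear on this change, since they concern the same carbonyl carbon, but the entering 5-ethylpyrimidin-2-yl is unlike cyclobutyloxy, cyclobutylsulfanyl or 1-fluoro-1-methylethyl, so they guide only loosely. Because a number 7 percentage points lower from compound 1 to compound 3 (within the scatter) and a number 7 percentage points lower from compound 2 to compound 3 (within the scatter) stayed within the scatter, no step beyond the scatter is expected here either, a number 4 percentage points higher from compound 3 to compound 4 (within the scatter). Compound 4 is expected to give 78% in this assay, with a range of 64% to 92%.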

Compound 4, largest response reached (reported as efficacy), in percent of the reference or control that the assay uses: 80%
Compound 4: the middle estimate sits 2 percentage points below what was measured, and the stated range covers the measured number.
By their numbers in this assay, from the lowest: compounds 3, 4, 1 and 2 (each within the scatter of the next).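

In this assay the steps are a number 6 percentage points higher from compound 3 to compound 4 (within the scatter) and a number 1 percentage points lower from compound 2 to compound 4 (within the scatter) and a number 1 percentage points lower from compound 1 to compound 4 (within the scatter), so a six-membered aromatic ring with 2 hetero atoms can sit on this carbonyl carbon with the read-out staying within the scatter of all three earlier compounds. Among the compounds shown here, the position now holds cyclobutyloxy, cyclobutylsulfanyl, 1-fluoro-1-methylethyl and 5-ethylpyrimidin-2-yl, the last with 8 heavy atoms, and no step among them goes beyond the scatter. Nothing at hand explains why the read-out stays level across these groups.

Going by these compounds, whether an amine, a carboxylic acid or a longer alkyl chain on the carbonyl carbon would keep the read-out in this range stays open. Also open, on these data alone, is whether these four groups would separate on any read-out other than largest response.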